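Chloro for Fluoro on the Core of Compound 3

The source may hold more compounds than are shown below. What is called first, only, known or untested is meant among the compounds shown, and "the series" means these compounds.

In an assay on isolated protein for displacement of a labelled ligand from metabotropic glutamate receptor 5 (Homo sapiens), with a stated time of 60 min, tested at 1 uM (on this read-out lower numbers stand for less inhibition and higher numbers for more inhibition at the one concentration tested (going by the name of the read-out)), compound 3 `CC1CCN(c2c(S(=O)(=O)c3ccc(C#N)cc3)cnc3ccc(F)cc23)CC1` gives 75%, the second highest of the three numbers. Compound 2 `Cc1ccc(S(=O)(=O)c2cnc3ccc(Cl)cc3c2N2CCC(C)CC2)cc1Cl` gives 81%, which lies within the scatter of compound 3, while compound 1 `CC1CCN(c2c(S(=O)(=O)c3cccc(F)c3)cnc3ccc(Cl)cc23)CC1` gives 58%, beyond the scatter below it. Compound 4 `CC1CCN(c2c(S(=O)(=O)c3ccc(C#N)cc3)cnc3ccc(Cl)cc23)CC1` differs from compound 3 by chloro in place of fluoro on an aromatic carbon. Going by the values given here, the single measured step, a number 23 percentage points higher from compound 1 to compound 2 (beyond the scatter), alters the aryl on the sulfonyl sulfur rather than the fused core, so it does not bear on this change; compounds 1 and 2 both already carry chloro there, and no measured pair isolates the core halogen. Compound 4 is therefore expected to show no step beyond the scatter in this assay, no change at the digits printed from compound 3 to compound 4 (within the scatter). The value of compound 4 is estimated at 75%, within 60% to 88%.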

Compound 4, a percentage reported as inhibition, at one concentration (the size of the read-out at that concentration, not a potency): 31%
Beside the measured number, compound 4's estimate is 44 percentage points above it, and the stated range ends above it.
By their numbers in this assay, from the lowest: compound 4; then compound 1; then compounds 3 and 2 (each within the scatter of the next).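

In this assay, going by these compounds alone, the halogen on the core matters far more than the earlier compounds could show: with 4-cyanophenyl on the sulfonyl sulfur, chloro in place of fluoro brings a number 44 percentage points lower from compound 3 to compound 4 (beyond the scatter) on that aromatic carbon. With chloro held on the core, 4-cyanophenyl in place of 3-chloro-4-methylphenyl brings a number 50 percentage points lower from compound 2 to compound 4 (beyond the scatter) and in place of 3-fluorophenyl brings a number 27 percentage points lower from compound 1 to compound 4 (beyond the scatter) as the lowest of the three. No measurement offered here accounts for this drop. On these data alone, whether the halogen step keeps its size with another aryl on the sulfonyl sulfur stays open. So does what methoxy or an amine on that carbon would give.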